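Amine replacements on the basic side chain

The source may hold more compounds than are shown below. What is called first, only, known or untested is meant among the compounds shown, and "the series" means these compounds.

Three compounds share one core and differ only in the amine on the saturated chain. In an assay on CHO-K1 cells for binding affinity to muscarinic acetylcholine receptor M5 (Homo sapiens) (on this read-out higher numbers stand for weaker inhibition and lower numbers for stronger inhibition), compound 1 `CC(C1=C(CCN2CCCCC2)Cc2ccccc21)c1ccccn1` gives 2340 nM, compound 2 `CCN(CC)CCC1=C(C(C)c2ccccn2)c2ccccc2C1` gives 2090 nM, and compound 3 `CC(C1=C(CCN(C)C(C)C)Cc2ccccc21)c1ccccn1` gives 2190 nM. The steps of a 1.1-fold lower number from compound 1 to compound 2 (0.05 log units; within the scatter), a 1.1-fold lower number from compound 1 to compound 3 (0.03 log units; within the scatter) and a 1.0-fold higher number from compound 2 to compound 3 (0.02 log units; within the scatter) all stay inside the scatter. Compound 3 stands second highest of the three, closest to compound 2 and furthest from compound 1, both gaps within the scatter. Compound 4 `CC(C1=C(CCCN(C)C)Cc2ccccc21)c1ccccn1` carries (dimethylamino)methyl in place of isopropyl(methyl)amino on a saturated chain carbon, two bonds along the chain from a double-bonded ring carbon. The three measured amine exchanges, every one within the scatter, bear directly on this further exchange, so no shift beyond the scatter is expected in this assay, and a 1.0-fold higher number from compound 3 to compound 4 (0.00 log units; within the scatter) is the estimated step. For compound 4 the expected value is 2200 nM, with a range from 900 nM to 5500 nM.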

Compound 4, inhibition constant: 3240 nM
The estimate for compound 4 lay 1.5-fold (0.17 log units) below the measured number; the range from low to high includes it.
By their numbers in this assay, from the lowest: compounds 2, 3, 1 and 4 (each within the scatter of the next).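

Replacing the amine also changes the chain at this position, from 2-(isopropyl(methyl)amino)ethyl to 3-(dimethylamino)propyl, yet this assay gives a 1.5-fold higher number from compound 3 to compound 4 (0.17 log units; within the scatter), a 1.6-fold higher number from compound 2 to compound 4 (0.19 log units; within the scatter) and a 1.4-fold higher number from compound 1 to compound 4 (0.14 log units; within the scatter). All four compounds therefore remain within the scatter of the next, so this longer chain with its smaller amine gives no separable change. No supporting measurement bears on this result.

A 2-(dimethylamino)ethyl group would separate the effect of the amine from that of chain length. Also open, on these data alone, is how a 4-(dimethylamino)butyl chain or a carboxylic acid in place of the amine would read here.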